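Swapping the Sulfonyl Aryl Group in a Kinase-Like Series

The compounds below may be only part of what the source reports. "The series", "measured", "known", "first", "only" and "open" are said of these compounds alone.

Compound 1 `O=S(=O)(NCCCNc1nccc(-c2c(-c3cccc(F)c3)nc3sccn23)n1)c1cccc(F)c1` is measured in a functional assay on A-375 cells (Homo sapiens) for cytotoxicity, read by MTT assay (on this read-out higher numbers stand for weaker inhibition and lower numbers for stronger inhibition), where compound 1 gives 13700 nM. That is the second highest of the three numbers recorded: compound 2 `O=S(=O)(NCCCNc1nccc(-c2c(-c3cccc(F)c3)nc3sccn23)n1)c1ccccc1` gives 6600 nM, and compound 3 `O=S(=O)(NCCNc1nccc(-c2c(-c3cccc(F)c3)nc3sccn23)n1)c1ccc(Cl)cc1` gives 18600 nM. Compound 4 `O=S(=O)(NCCCNc1nccc(-c2c(-c3cccc(F)c3)nc3sccn23)n1)c1ccc(Cl)cc1` differs from compound 1 in one place: 4-chlorophenyl in place of 3-fluorophenyl on a sulfonyl sulfur. Among the measured compounds shown here, no measured step changes only the aryl group on the sulfonyl sulfur while keeping the three-carbon chain. The nearest guide is a 1.4-fold higher number from compound 1 to compound 3 (0.13 log units; within the scatter), which also shortens the chain, and a 2.8-fold higher number from compound 2 to compound 3 (0.45 log units; beyond the scatter). The step in this assay from compound 1 to compound 4 is therefore expected to be small, a 1.1-fold higher number from compound 1 to compound 4 (0.04 log units; within the scatter). Compound 4 is estimated at 15000 nM, with a range from 6500 nM to 35000 nM.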

Compound 4, half-maximal inhibitory concentration: 5900 nM
The estimate for compound 4 lay 2.5-fold (0.41 log units) above the measured number, and the stated range ends above it.
By their numbers in this assay, from the lowest: compounds 4 and 2 (each within the scatter of the next); then compounds 1 and 3 (each within the scatter of the next).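

The swap on the sulfonyl sulfur gives a real step in this assay (a 2.3-fold lower number from compound 1 to compound 4 (0.37 log units; beyond the scatter)), yet the chloro compound cannot be told apart from the unsubstituted phenyl compound (a 1.1-fold lower number from compound 2 to compound 4 (0.05 log units; within the scatter)). With 4-chlorophenyl held fixed, the chain step can now be read on its own (a 3.2-fold lower number from compound 3 to compound 4 (0.50 log units; beyond the scatter)). No evidence here explains these steps. Still open, as far as these compounds go, is how a 4-methoxyphenyl or a plain methyl on the sulfonyl sulfur would compare with compound 4, and whether a longer chain would move the number further.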